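Adding a second trifluoromethyl group to compound 2

The compounds below may be only part of what the source reports. "The series", "measured", "known", "first", "only" and "open" are said of these compounds alone.

- Compound 1 `CC(O)(CS(=O)(=O)c1cccc(S(F)(F)(F)(F)F)c1)C(=O)Nc1ccc(S(F)(F)(F)(F)F)cc1`: 34000 nM
- Compound 2 `CC(O)(CS(=O)(=O)c1cccc(C(F)(F)F)c1)C(=O)Nc1ccc(S(F)(F)(F)(F)F)cc1`: 31900 nM
- Compound 3 `CC(O)(CS(=O)(=O)c1ccccc1C(F)(F)F)C(=O)Nc1ccc(S(F)(F)(F)(F)F)cc1`: 29400 nM

In a functional assay on DU-145 cells (Homo sapiens) for antiproliferative activity, read by propidium iodide staining, with a stated time of 96 h (on this read-out lower numbers stand for stronger inhibition and higher numbers for weaker inhibition), compound 2 gives 31900 nM, which lies within the scatter of the other two values. Compound 4 `CC(O)(CS(=O)(=O)c1cc(C(F)(F)F)cc(C(F)(F)F)c1)C(=O)Nc1ccc(S(F)(F)(F)(F)F)cc1` has trifluoromethyl in place of hydrogen on an aromatic carbon, meta to a trifluoromethyl group (trifluoromethyl in place of hydrogen on an aromatic carbon). For the measured compounds named here, two measured steps bear on this change: a 1.1-fold lower number from compound 1 to compound 2 (0.03 log units; within the scatter) and a 1.1-fold lower number from compound 2 to compound 3 (0.04 log units; within the scatter). Both alter the aryl group on the sulfonyl sulfur, and both are small. Neither adds a second group, however, so they offer only loose guidance. No step beyond the scatter is therefore expected in this assay, with an estimated 1.1-fold lower number from compound 2 to compound 4 (0.03 log units; within the scatter). Compound 4 is expected at 30000 nM, within an estimated range of 14000 nM to 60000 nM.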

Compound 4, half-maximal inhibitory concentration: 24400 nM
Compound 4: the middle estimate sits 1.2-fold (0.09 log units) above what was measured; the range from low to high includes it.
By their numbers in this assay, from the lowest: compounds 4, 3, 2 and 1 (each within the scatter of the next).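

In this assay, adding a second trifluoromethyl group to the aromatic ring gives a 1.3-fold lower number from compound 2 to compound 4 (0.12 log units; within the scatter) and stays within the scatter. The earlier compounds shown here only exchanged or moved a group, whereas this result shows that a true addition at this position also leaves the number essentially unchanged. No measurement given here accounts for this result. Still open, as far as these compounds go, is whether a different kind of group at this position, such as an amine or a carboxylic acid, would shift the number beyond the scatter.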